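The compounds below may be only part of what the source reports. "The series", "measured", "known", "first", "only" and "open" are said of these compounds alone.

Measured so far:
Compound 1, `NC1=NC2(CCSCC2)N(OCCCOc2cccc(Cl)c2)C(N)=N1`, with 88.8% in an assay on isolated protein for inhibition of Dihydrofolate reductase (Homo sapiens), read by spectrophotometry, using NADPH, with stated times of 5 s and 6 min, tested at 50 uM; a lower number here means a weaker effect, a higher number a stronger effect of the compound at the concentration tested.
Compound 2, `NC1=NC2(CCOCC2)N(OCCCOc2ccccc2Cl)C(N)=N1`, with 88.2% in this assay.

Compound 1 has the higher of the two numbers, yet the gap to compound 2 lies within the scatter, so the two cannot be told apart on these data. Among the measured compounds shown here, both share the same core, and they differ in two places at once, so no single step between measured compounds is available.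

Compound 3, `NC1=NC2(CCSCC2)N(OCCCOc2ccccc2Br)C(N)=N1`, has not yet been measured. It differs from compound 1 in one place: 2-bromophenyl in place of 3-chlorophenyl on an oxygen on a saturated carbon. Compound 2 shows that a halogen on the 2-position of the phenyl ring still gives 88.2%, so no step beyond the scatter is expected in this assay from compound 1 to compound 3, that is a number 2.8 percentage points lower from compound 1 to compound 3 (within the scatter). Compound 3 is therefore estimated at 86%, with a range from 72% to 95%.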

Compound 3, a percentage reported as inhibition, at one concentration (the size of the read-out at that concentration, not a potency): 89.6%
For compound 3 the middle estimate is 3.6 percentage points below the measured one, within the range that was stated.
By their numbers in this assay, from the lowest: compounds 2, 1 and 3 (each within the scatter of the next).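

Among the compounds shown here, putting 2-bromophenyl in place of 3-chlorophenyl on an oxygen on a saturated carbon gives a number 0.8 percentage points higher from compound 1 to compound 3 (within the scatter) in this assay and is the first step that differs in only one place. It shows that changing the halogen and its place on the phenyl ring in a single step leaves the two compounds indistinguishable at this one concentration, although that step cannot separate the two changes and a read-out at one concentration is not a potency. Nothing available offers a reason for this result.

Every compound shown carries a halogen on the phenyl ring, so it remains open how a plain phenyl, or a ring bearing an amine or a carboxylic acid, would read in this assay. Also open, as far as these compounds go, is what a longer chain to the phenoxy group would do.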